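Chain length at the carbamate oxygen: ethyl homologue

The source may report more compounds than this note shows. Statements on the series, on what has been measured and on what is new or still open speak of the compounds shown alone.

Measured so far in an ADME assay on BEAS-2B cells (Homo sapiens) for cytotoxicity, read by MTT assay, with a stated time of 72 h; on this read-out lower numbers stand for stronger inhibition of growth and higher numbers for weaker inhibition of growth:
compound 1, `CC(C)COC(=O)Nc1ccc([Se]C#N)cc1`: 26900 nM
compound 2, `CCCCCCOC(=O)Nc1ccc([Se]C#N)cc1`: 2800 nM

Compound 2 gives the lowest of the two numbers; its nearest neighbour, compound 1, sits a clear step higher, and that step, a 9.6-fold lower number from compound 1 to compound 2 (0.98 log units; beyond the scatter), is the only measured one in the series. The next compound, compound 3, `CCOC(=O)Nc1ccc([Se]C#N)cc1`, is not yet measured. It differs from compound 2 by hydrogen in place of butyl on a saturated chain carbon, two bonds along the chain from an oxygen next to a carbonyl group.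

For the measured compounds named here, the one step bears directly on this change, since it also alters the chain at the oxygen next to the carbonyl and shows a lower number for the longer chain. Compound 3 carries the shortest chain of the three, so a higher number than compound 2, and likely than compound 1, is expected in this assay; the size is uncertain with a single step. The expected step is a 14-fold higher number from compound 2 to compound 3 (1.15 log units; beyond the scatter). Compound 3 is expected near 40000 nM, within 10000 nM to 150000 nM.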

Compound 3, concentration for 50% growth inhibition: 21700 nM
The estimate for compound 3 lay 1.8-fold (0.27 log units) above the measured number; the range from low to high includes it.
By their numbers in this assay, from the lowest: compound 2; then compounds 3 and 1 (each within the scatter of the next).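

In this assay, the change from hexyl to ethyl gives a 7.8-fold higher number from compound 2 to compound 3 (0.89 log units; beyond the scatter), so a second, shorter chain now separates from the hexyl chain of compound 2. The other new step, a 1.2-fold lower number from compound 1 to compound 3 (0.09 log units; within the scatter), shows no separation between the chains of compound 1 and compound 3, so this position does not read as a steady dependence on chain size across the three compounds; only compound 2 stands apart. No measurement at hand accounts for the difference between hexyl and the two shorter chains.

Open, from the compounds shown here alone, is where between ethyl and hexyl the number shifts, which a butyl or pentyl chain at the same oxygen would help to place. Also open, going by these compounds, is whether a chain longer than hexyl, or a benzyl group, continues the step or reverses it.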